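A few compounds are considered here, and "the series" means these few. Any claim that something is new, unique, unknown or untested is made for them only; others in the source may bear on it.

Compound 2 `CNC(=O)c1cc(C(=O)NC2CC2)cn([C@H](C)c2ccccc2)c1=O` is the more lipophilic of the two measured compounds on this read-out. In a physicochemical assay for lipophilicity, at pH 7.4 (on this read-out higher numbers stand for higher lipophilicity and lower numbers for lower lipophilicity), compound 2 gives 3.4, whereas compound 1 `CNC(=O)c1cc(C(=O)NC2CC2)cn(Cc2ccc3nc[nH]c3c2)c1=O` in this assay gives 1.2, a gap that lies beyond the scatter. Compound 3 `CNC(=O)c1cc(C(=O)NC2CC2)cn(Cc2cccc(F)c2)c1=O` has not yet been measured. It differs from compound 2 in one place: 3-fluorobenzyl in place of 1-phenylethyl on an aromatic nitrogen. For the measured compounds named here, no measured pair in this set shows the same kind of change, so the expectation rests on the two values alone and on the change itself, in which a group of 8 heavy atoms, all carbon, is replaced by another of 8 heavy atoms, one of them fluorine. From compound 2 to compound 3 a small step is expected, a number 0.30 log units lower from compound 2 to compound 3 (within the scatter), at most slightly downward and possibly within the scatter. Compound 3 is therefore estimated at 3.1 in this assay, with a range from 2.6 to 3.6.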

Compound 3, distribution coefficient: 3.2
The estimate for compound 3 lay 0.10 log units below the measured number; the range from low to high includes it.
By their numbers in this assay, from the lowest: compound 1; then compounds 3 and 2 (each within the scatter of the next).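

On the aromatic nitrogen, in this assay, putting 3-fluorobenzyl in place of 1-phenylethyl gives a number 0.20 log units lower from compound 2 to compound 3 (within the scatter), so this exchange of two groups of equal heavy-atom count, which also removes the defined stereocentre, stays within the scatter. Exchanging the ring group on the saturated chain carbon gives a far larger step, a number 2.00 log units higher from compound 1 to compound 3 (beyond the scatter), so among these three compounds the large difference goes with 3-fluorophenyl in place of 1H-benzimidazol-6-yl, not with the change from 1-phenylethyl. Nothing in the available data explains either step.

The compounds shown leave open how a plain benzyl group would read, which would separate the fluorine from the rest of this exchange, and how the mirror-image form of 1-phenylethyl would compare. They also leave open what an amine or a carboxylic acid in this same place would give in this assay.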